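This account rests on a few compounds, and the source may have more. Where it says the series, first, only, none or still open, it means among the compounds named here.

Values so far in a functional assay on Bel7402/5-FU cells (Homo sapiens) for antiproliferative activity, read by MTT assay, with a stated time of 72 h; on this read-out lower numbers stand for stronger inhibition and higher numbers for weaker inhibition:
- compound 1 `C=C1C(=O)O[C@H]2[C@H]1CC/C(Cn1cc(Cn3cc(F)c(=O)[nH]c3=O)nn1)=C\CC[C@@]1(C)O[C@@H]21`: > 20000 nM (a limit of the assay)
- compound 2 `C=C1C(=O)O[C@H]2[C@H]1CC/C(COC(=O)Cn1cc(F)c(=O)n(Cc3ccccc3)c1=O)=C\CC[C@@]1(C)O[C@@H]21`: 4270 nM
- compound 3 `C=C1C(=O)O[C@H]2[C@H]1CC/C(Cn1cc(Cn3cc(F)c(=O)n(Cc4ccccc4)c3=O)nn1)=C\CC[C@@]1(C)O[C@@H]21`: 8840 nM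

Compound 1 gives no number, only a limit: the limit of > 20000 nM in this assay, at which 1 of the 3 values shown sits, is all that can be read from it. Of the two actual numbers, compound 2 holds the lower at 4270 nM and compound 3 reads 8840 nM with the gap beyond the scatter.

The next step leads to compound 4 `C=C1C(=O)O[C@H]2[C@H]1CC/C(COC(=O)Cn1cc(F)c(=O)n(Cc3cccc(F)c3)c1=O)=C\CC[C@@]1(C)O[C@@H]21` and is small: fluoro in place of hydrogen on an aromatic carbon is the whole difference, fluoro in place of hydrogen on an aromatic carbon, which turns benzyl into 3-fluorobenzyl.

Among the measured compounds shown here, only one measured step touches this benzyl group. It is an at least 2.2-fold lower number from compound 1 to compound 3 (0.35 log units; beyond the scatter) for benzyl in place of hydrogen on an aromatic nitrogen, a step that adds the whole group and is at least modest in size. For the measured compounds named here, no measured step substitutes the benzyl ring, so this gives little guidance on a single fluoro, and the anchor stays compound 2 at 4270 nM as the closest measured neighbour.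

The expected change is a 1.1-fold lower number from compound 2 to compound 4 (0.05 log units; within the scatter) and no shift beyond the scatter is expected in this assay in either direction.

For compound 4 the estimated value is 3800 nM with an expected range from 1600 nM to 9000 nM as the working window.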

Compound 4, half-maximal inhibitory concentration: 3700 nM
Compound 4: middle estimate off by 1.0-fold (0.01 log units), on the high side, within the range that was stated.
By their numbers in this assay, from the lowest: compounds 4 and 2 (each within the scatter of the next); then compound 3. At a limit, above all of these: compound 1.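

In this assay the change to 3-fluorobenzyl reads as a 1.2-fold lower number from compound 2 to compound 4 (0.06 log units; within the scatter) and so places a single fluoro on this aromatic carbon, meta to a large group, without a separable change in the read-out. Among the compounds shown here, the only earlier step touching this group was an at least 2.2-fold lower number from compound 1 to compound 3 (0.35 log units; beyond the scatter) and it added the whole benzyl group on the aromatic nitrogen, which said nothing about a substituent on the ring itself. Nothing measured in this set accounts for the size of the new step.

Open, going by these compounds, is whether a larger group on the same ring, such as trifluoromethyl or methoxy, or a charged one such as an amine or a carboxylic acid, would move the number beyond the scatter, and whether fluoro elsewhere on the ring reads the same way. Also open, on these data alone, is whether 3-fluorobenzyl behaves on the linker of compound 3 as it does on the linker of compound 2, since one fluoro step on one linker does not settle that.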